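A few compounds are considered here, and "the series" means these few. Any claim that something is new, unique, unknown or untested is made for them only; others in the source may bear on it.

In a functional assay on M21 cells (Homo sapiens) for antiproliferative activity, read by sulforhodamine B assay, with a stated time of 48 h (a higher number here means a weaker inhibitor, a lower number a stronger inhibitor), compound 1 `Cc1ccccc1OS(=O)(=O)c1ccc(N2CCN(C)C2=O)cc1` gives 2900 nM, and compound 2 `CN1CCN(c2ccc(S(=O)(=O)Oc3cc(Cl)c(Cl)cc3Cl)cc2)C1=O` gives 420 nM. Compound 3 `CCCN1CCN(c2ccc(S(=O)(=O)Oc3ccccc3C)cc2)C1=O` reads > 100000 nM, which is a limit of the assay and not a number. Compound 3 therefore has no exact place on the scale. Compound 4 `CCCN1CCN(c2ccc(S(=O)(=O)Oc3cccc(C)c3)cc2)C1=O` differs from it as follows: 3-methylphenyl in place of 2-methylphenyl on an oxygen, with 3-methylphenyl in place of 2-methylphenyl on an oxygen. Within the data shown here, the one measured step that bears on this is large: an at least 34-fold higher number from compound 1 to compound 3 (1.53 log units; beyond the scatter), with ethyl in place of hydrogen on a saturated chain carbon. Among the measured compounds shown here, compound 4 keeps that chain, and no measured step covers the methyl move, so only a modest shift towards a lower number in this assay is expected. The expected change is an at least 1.6-fold lower number from compound 3 to compound 4 (0.22 log units; that floor lies within the scatter). For compound 4 the estimated value is 60000 nM, within a range of 8000 nM to 150000 nM.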

Compound 4, half-maximal inhibitory concentration: 28000 nM
For compound 4 the middle estimate is 2.1-fold (0.33 log units) above the measured one, and the stated range covers the measured number.
By their numbers in this assay, from the lowest: compound 2; then compound 1; then compound 4. At a limit, above all of these: compound 3.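

Compound 4 shows that the place of the methyl on this ring matters, not only the chain on the other side of the core. In this assay, 3-methylphenyl in place of 2-methylphenyl on the oxygen bound to the sulfonyl sulfur gives an at least 3.5-fold lower number from compound 3 to compound 4 (0.55 log units; beyond the scatter), with the same atoms throughout. That step is only a floor because compound 3 reads at a limit: the limit of > 100000 nM in this assay, at which 1 of the 4 values shown sits.

Still open, on these data alone, is whether the same methyl move would help with the methyl on the ring nitrogen of compound 1. Also open, as far as these compounds go, is how an amine or a carboxylic acid on this ring would read.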